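This account rests on a few compounds, and the source may have more. Where it says the series, first, only, none or still open, it means among the compounds named here.

Compound 3 `CN(C(=O)NC(=O)c1ccc(C(F)(F)F)cc1)c1nc(C(F)(F)F)c(C(=O)N/N=C/c2ccc(C(F)(F)F)cc2)s1` carries a 4-(trifluoromethyl)phenyl on the carbonyl carbon of the acylurea. In a functional assay on BCG823 cells (Homo sapiens) for inhibition, read by MTT assay, with a stated time of 72 h (on this read-out lower numbers stand for stronger inhibition and higher numbers for weaker inhibition), compound 3 gives only a limit, > 100 ug/mL, so no number stands for it (the limit of > 100 ug/mL in this assay, at which 1 of the 3 values shown sits). Compound 1 `CN(C(=O)NC(=O)c1ccc(F)c(F)c1)c1nc(C(F)(F)F)c(C(=O)N/N=C/c2ccc(C(F)(F)F)cc2)s1` gives 3.85 ug/mL in this assay, and compound 2 `CN(C(=O)NC(=O)c1cccc(C(F)(F)F)c1)c1nc(C(F)(F)F)c(C(=O)N/N=C/c2ccc(C(F)(F)F)cc2)s1` gives 4.22 ug/mL; a 1.1-fold higher number from compound 1 to compound 2 (0.04 log units; within the scatter). Both an at least 25-fold higher number from compound 1 to compound 3 (1.41 log units; beyond the scatter) and an at least 23-fold higher number from compound 2 to compound 3 (1.37 log units; beyond the scatter) mark the 4-(trifluoromethyl)phenyl as the weak member. Compound 4 `CN(C(=O)NC(=O)c1c(F)cccc1F)c1nc(C(F)(F)F)c(C(=O)N/N=C/c2ccc(C(F)(F)F)cc2)s1` differs from compound 3 by 2,6-difluorophenyl in place of 4-(trifluoromethyl)phenyl on a carbonyl carbon. Since both arenes other than 4-(trifluoromethyl)phenyl sit near compound 1 3.85 ug/mL, a return to a measurable number is expected, so an at least 12-fold lower number from compound 3 to compound 4 (1.09 log units; beyond the scatter). Compound 4 is estimated at 8 ug/mL in this assay, within 2 ug/mL to 60 ug/mL.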

Compound 4, half-maximal inhibitory concentration: 34.9 ug/mL
Beside the measured number, compound 4's estimate is 4.4-fold (0.64 log units) below it; the range from low to high includes it.
By their numbers in this assay, from the lowest: compounds 1 and 2 (each within the scatter of the next); then compound 4. At a limit, above all of these: compound 3.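

In this assay, 2,6-difluorophenyl on the carbonyl carbon does not reach the level of the other two arenes: an 8.3-fold higher number from compound 2 to compound 4 (0.92 log units; beyond the scatter) and a 9.1-fold higher number from compound 1 to compound 4 (0.96 log units; beyond the scatter). Against 4-(trifluoromethyl)phenyl, the change gives an at least 2.8-fold lower number from compound 3 to compound 4 (0.45 log units; beyond the scatter), so this position now separates three arenes rather than two levels alone. Compound 3 remains a limit and not a number: the limit of > 100 ug/mL in this assay, at which 1 of the 4 values shown sits.

Open, as far as these compounds go, is how a single fluorine, as in 2-fluorophenyl or 4-fluorophenyl, would stand on this carbonyl carbon. Also open, from the compounds shown here alone, is how a 4-aminophenyl or a 4-carboxyphenyl would stand there.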